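This account rests on a few compounds, and the source may have more. Where it says the series, first, only, none or still open, it means among the compounds named here.

Measured so far:
Compound 1, `O=C(CCc1ccc(C(F)(F)F)cc1)Nc1ccc2nc(N3CCC(c4ccccc4)C3)ccc2c1`, gives 1770 nM.
Compound 2, `O=C(CCc1ccc(C(F)(F)F)cc1)Nc1ccc2nc(N3CC4CC3CO4)ccc2c1`, gives 70 nM.

These two compounds share one core and differ only in the group attached to the aromatic carbon next to the ring nitrogen. In a functional assay on HEK293 cells for activation of melanin-concentrating hormone receptor 1 (Rattus norvegicus), read by inositol phosphate accumulation (a higher number here means that more compound is needed for the effect, a lower number that less compound is needed), compound 1 gives 1770 nM, while compound 2 gives 70 nM, the lowest of the two numbers; the step of a 25-fold lower number from compound 1 to compound 2 (1.40 log units; beyond the scatter) is large and well beyond the scatter, so the group at this position clearly governs the read-out.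

Going by the values given here, compound 3, `O=C(CCc1ccc(C(F)(F)F)cc1)Nc1ccc2nc(N3CC4CCC3CC4)ccc2c1`, keeps the whole amide side and the core of compound 2 and changes only that group: a group of 8 heavy atoms (7 carbon, 1 nitrogen; 2 six-membered non-aromatic rings with 1 hetero atom each) in place of a group of 7 heavy atoms (5 carbon, 1 nitrogen, 1 oxygen; 2 five-membered non-aromatic rings with 1 hetero atom each), on an aromatic carbon. Among the compounds with values here, no measured step bears directly on this exchange. Within the data shown here, the only comparison available, the step from compound 1 to compound 2, shows that a change at this position can move the number a long way, but it tells nothing specific about exchanging an oxygen-containing bicyclic group for a carbon-only one of similar size.

Given the loss of one hydrogen-bond acceptor and the enlargement of both rings, compound 3 is expected to give a somewhat higher number than compound 2, a step of a 2.9-fold higher number from compound 2 to compound 3 (0.46 log units; beyond the scatter), though a result within the scatter would not surprise. The estimate for compound 3 in this assay is 200 nM, with a range from 50 nM to 800 nM.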

Compound 3, half-maximal effective concentration: 190 nM
Compound 3: the middle estimate sits 1.1-fold (0.02 log units) above what was measured, and the stated range covers the measured number.
By their numbers in this assay, from the lowest: compound 2; then compound 3; then compound 1.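

In this assay, putting the carbon-only bridged group in place of the oxygen-containing one gives a 2.7-fold higher number from compound 2 to compound 3 (0.43 log units; beyond the scatter), a modest change that still lies beyond the scatter, which shows that two bridged groups of nearly equal heavy-atom count can be told apart at this position next to the ring nitrogen, though by far less than the earlier step between compounds with very different groups. The carbon-only group also stands well clear of the group of compound 1, with a 9.3-fold lower number from compound 1 to compound 3 (0.97 log units; beyond the scatter), so oxygen in the bridged group is not required for a number well under that of compound 1, even though compound 2 still gives the lowest number of the three. Nothing available accounts for the difference between the two bridged groups.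

The exchange from compound 2 to compound 3 alters the oxygen and both ring sizes together, and the share of each in the step remains unresolved. As far as these compounds go, whether an unbridged morpholine, or a bridged group carrying an added amine, would lower or raise the number at this position also remains open.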